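Second bromine on the hydroxyphenyl arm of a quinazoline urea

The compounds below may be only part of what the source reports. "The series", "measured", "known", "first", "only" and "open" are said of these compounds alone.

The three measured compounds share the aminoquinazoline urea motif and differ at two points. Compound 2 `O=C(N/N=C/c1ccc(O)cc1)Nc1cc2c(Nc3ccc(F)c(Cl)c3)ncnc2cc1O[C@H]1CCOC1` gives 1320 nM in a functional assay on A549 cells (Homo sapiens) for cytotoxicity, read by MTT assay, with a stated time of 72 h; on this read-out lower numbers stand for stronger inhibition and higher numbers for weaker inhibition. Compound 1 `O=C(N/N=C/c1ccc(O)c(Br)c1)Nc1cc2c(Nc3ccc(F)c(Cl)c3)ncnc2cc1O[C@H]1CCOC1` carries bromo in place of hydrogen on an aromatic carbon, and in this assay compound 1 gives 4310 nM, so that a 3.3-fold higher number from compound 2 to compound 1 (0.51 log units; beyond the scatter). Compound 3 `COc1cc2ncnc(Nc3ccc(F)c(Cl)c3)c2cc1NC(=O)N/N=C/c1ccc(O)c(Br)c1` differs from compound 1 by methyl in place of oxolan-3-yl on an oxygen on an aromatic ring, and in this assay compound 3 gives 28600 nM; the result is a 6.6-fold higher number from compound 1 to compound 3 (0.82 log units; beyond the scatter). How the core of compound 3 differs from that of compound 2 is not broken down here; their values alone show the gap: compound 2 gives 1320 nM, whereas compound 3 gives 28600 nM. Compound 3 therefore stands with the highest number of the three.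

Compound 4 `COc1cc2ncnc(Nc3ccc(F)c(Cl)c3)c2cc1NC(=O)N/N=C/c1cc(Br)c(O)c(Br)c1` has not been measured. Relative to compound 3 it carries bromo in place of hydrogen on an aromatic carbon. This is the same kind of change as that from compound 2 to compound 1, but the place is not identical: in compound 4 the entering bromo is also meta to a bromo group already present. Within the data shown here, from the one measured example of this change, a 3.3-fold higher number from compound 2 to compound 1 (0.51 log units; beyond the scatter), a step of similar direction is expected, so that a 2.4-fold higher number from compound 3 to compound 4 (0.39 log units; beyond the scatter) is estimated. Compound 4 is accordingly expected to give about 70000 nM in this assay, within a range from 25000 nM to 200000 nM, with a real chance that only a limit is reported.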

Compound 4, half-maximal inhibitory concentration: 34600 nM
Beside the measured number, compound 4's estimate is 2.0-fold (0.31 log units) above it; measured number inside the range.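

On the core of compound 3, bromo in place of hydrogen gives a 1.2-fold higher number from compound 3 to compound 4 (0.08 log units; within the scatter) in this assay, so this read-out does not separate the two compounds. Among these compounds, the same replacement therefore does not carry over at the same size from one core to the other, since it is beyond the scatter on the core of compound 2 and within it on the core of compound 3: the same change on two cores in this assay, a 3.3-fold higher number (0.51 log units; beyond the scatter) from compound 2 to compound 1 and a 1.2-fold higher number (0.08 log units; within the scatter) from compound 3 to compound 4, 2.7-fold (0.43 log units) apart, beyond the scatter of two such steps This does not show that the core alone sets the size of the step: there are only two pairs, and they differ in the place as well, since the bromo entering compound 4 is meta to a bromo group, a feature printed only for this step, so the two influences cannot be separated here, and neither pair gives a reason for the gap.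

The compounds shown leave open how the 3,5-dibromo-4-hydroxyphenyl arm would read on the core of compound 1, which would set core and place apart. Also open, on these data alone, is how this assay would respond to an amine or a carboxylic acid in place of the entering bromo, or to a longer chain in place of the methyl on the oxygen.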